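Phenoxy for Cyanobenzyl: Acid Dissociation Expected Unchanged

The source may report more compounds than this note shows. Statements on the series, on what has been measured and on what is new or still open speak of the compounds shown alone.

Compound 3 `COc1ccc(F)cc1CNCCCNc1ccnc2cc(Cc3ccc(C#N)cc3)ccc12` gives 9.47 in a physicochemical assay for acid dissociation, level with compound 1 `COc1ccc(F)cc1CNCCCNc1ccnc2cc(Cc3cc(C)cc(C)c3)ccc12` at 9.47 and with compound 2 `COc1ccc(F)cc1CNCCCNc1ccnc2cc(CCC(C)C)ccc12` at 9.47. Compound 4 `COc1ccc(F)cc1CNCCCNc1ccnc2cc(Oc3ccccc3)ccc12` differs from compound 3 as follows: phenoxy in place of 4-cyanobenzyl on an aromatic carbon. For the measured compounds named here, the steps that bear on this are no change at the digits printed from compound 1 to compound 3 (within the scatter) and no change at the digits printed from compound 2 to compound 3 (within the scatter), and no change at the digits printed from compound 1 to compound 2 (within the scatter) shows the same; all three exchanged the group on the saturated chain carbon without moving the read-out, whereas the new step sits on an aromatic carbon of the shared core, so no earlier step covers it exactly. Because no change at the digits printed from compound 2 to compound 3 (within the scatter) and no change at the digits printed from compound 1 to compound 3 (within the scatter) showed nothing beyond the scatter, the expected step is no change at the digits printed from compound 3 to compound 4 (within the scatter), none beyond the scatter. Compound 4 is estimated at 9.47, between 9.15 and 9.8.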

Compound 4, acid dissociation constant: 9.28
Estimate against measurement, compound 4: 0.19 log units above; the measured number falls inside the stated range.
By their numbers in this assay, from the lowest: compounds 4, 1, 2 and 3 (each within the scatter of the next).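

In this assay the three new steps, a number 0.19 log units lower from compound 3 to compound 4 (within the scatter) and a number 0.19 log units lower from compound 2 to compound 4 (within the scatter) and a number 0.19 log units lower from compound 1 to compound 4 (within the scatter), all stay inside the scatter. The earlier compounds shown here exchanged only the group on the saturated chain carbon, whereas compound 4 shows that replacing the whole substituent on the aromatic carbon with phenoxy also gives no step beyond the scatter. Nothing available explains this result. Going by these compounds, whether an amine, a carboxylic acid or a longer chain on this aromatic carbon would also stay within the scatter remains open, as does a phenoxy bearing a nitrile.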